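Urea to amide on the shared core of compound 1

The source may hold more compounds than are shown below. What is called first, only, known or untested is meant among the compounds shown, and "the series" means these compounds.

Compound 1 `O=C(Nc1ccc(-n2ccc3nc(C(=O)NCc4ccccc4)ccc32)cc1)Nc1ccc(Cl)c(C(F)(F)F)c1` is the more potent of the two measured compounds in an ADME assay on HS27 cells (Homo sapiens) for cytotoxicity, read by MTT assay (a lower number here means a stronger inhibitor, a higher number a weaker inhibitor), where compound 1 gives 3000 nM. For the measured compounds named here, compound 2 `COC(=O)c1ccc2c(ccn2-c2ccc(NC(=O)Nc3ccc(Cl)c(C(F)(F)F)c3)cc2)n1` gives 8200 nM in this assay, and the only measured step, a 2.7-fold higher number from compound 1 to compound 2 (0.44 log units; beyond the scatter), concerns the carbonyl carbon on the opposite side of the molecule. Compound 3 `O=C(Nc1ccc(-n2ccc3nc(C(=O)NCc4ccccc4)ccc32)cc1)c1ccc(Cl)c(C(F)(F)F)c1` differs from compound 1 in a different place: 4-chloro-3-(trifluoromethyl)phenyl in place of (4-chloro-3-(trifluoromethyl)phenyl)amino on a carbonyl carbon. Going by the values given here, no measured step bears on this change directly; the step from compound 1 to compound 2 shows only that a modest alteration elsewhere moved the number beyond the scatter. On that basis the change is expected to leave the number of compound 3 close to that of compound 1, with a 1.3-fold higher number from compound 1 to compound 3 (0.12 log units; within the scatter) expected to stay within or only slightly beyond the scatter. Compound 3 is estimated at 4000 nM, within a range from 1500 nM to 11000 nM.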

Compound 3, half-maximal inhibitory concentration: 1500 nM
Compound 3: the middle estimate sits 2.7-fold (0.43 log units) above what was measured; the measured number falls inside the stated range.
By their numbers in this assay, from the lowest: compounds 3 and 1 (each within the scatter of the next); then compound 2.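

In this assay, the step at this carbonyl carbon, 4-chloro-3-(trifluoromethyl)phenyl in place of (4-chloro-3-(trifluoromethyl)phenyl)amino, gives a 2.0-fold lower number from compound 1 to compound 3 (0.30 log units; within the scatter), so the urea of compound 1 and the amide of compound 3 cannot be told apart here. For the compounds shown here, this is the first reading at this end of the molecule, as the earlier step concerned only the other carbonyl carbon, and it shows that the amino nitrogen with its hydrogen-bond donor can leave without a change beyond the scatter. Nothing given here explains why the number responds in this way.

On these data alone, it remains open whether a carbamate or a sulfonamide at this place would also stay within the scatter of compound 1. As far as these compounds go, it is equally open whether the same urea-to-amide change would read alike with the methoxy group of compound 2 on the other carbonyl carbon.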